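Lengthening the amine arm of a lipopeptide agonist

The source may hold more compounds than are shown below. What is called first, only, known or untested is meant among the compounds shown, and "the series" means these compounds.

Measured in an assay on HEK293 cells for agonist activity at Toll-like receptor 2 (Homo sapiens); a higher number here means that more compound is needed for the effect, a lower number that less compound is needed:
compound 1, `CCCCCCCCCCCC(=O)OC[C@H](CSC[C@@H](N)C(=O)NCCOCCOCCOCCC(=O)O)OC(=O)CCCCCCCCCCC`, gives 900 nM
compound 2, `CCCCCCCCCCCC(=O)OC[C@H](CSC[C@@H](N)C(=O)NCCN)OC(=O)CCCCCCCCCCC`, gives 5240 nM

For the measured compounds named here, of these two, compound 2 has the higher number; the only comparison available reads a 5.8-fold higher number from compound 1 to compound 2 (0.77 log units; beyond the scatter), so more of compound 2 is needed than of compound 1. Compound 3, `CCCCCCCCCCCC(=O)OC[C@H](CSC[C@@H](N)C(=O)NCCCCN)OC(=O)CCCCCCCCCCC`, is not yet measured. It differs from compound 2 by 2-aminoethyl in place of amino on a saturated chain carbon, two bonds along the chain from an amide-type nitrogen. Going by the values given here, only the step from compound 1 to compound 2 bears on this change, and only loosely: there one whole arm was exchanged for another, whereas here the amino group stays and its arm simply grows. That single step is the entire basis, so the direction is uncertain; a longer arm points back toward compound 1, and a step in this assay expected to be a 1.7-fold lower number from compound 2 to compound 3 (0.24 log units; within the scatter), a somewhat lower number, seems reasonable. Compound 3 is therefore estimated at 3000 nM, with a range from 900 nM to 10000 nM.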

Compound 3, half-maximal effective concentration: 1040 nM
Compound 3: the middle estimate sits 2.9-fold (0.46 log units) above what was measured; low and high end bracket the measured number.
By their numbers in this assay, from the lowest: compounds 1 and 3 (each within the scatter of the next); then compound 2.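

In this assay, 2-aminoethyl in place of amino gives a 5.0-fold lower number from compound 2 to compound 3 (0.70 log units; beyond the scatter) so lengthening the arm matters at this position, even with an amine still at its end. Replacing the 2-(2-(2-carboxyethoxy)ethoxy)ethoxy arm with 2-aminoethyl gives a 1.2-fold higher number from compound 1 to compound 3 (0.06 log units; within the scatter) so the earlier gap between the amine arm and the acid-ended arm does not hold once the amine arm is extended, and an acid end is not needed to reach this level. Nothing available explains why the added length has this effect.

A still longer carbon chain ending in an amine would show whether the trend continues or levels off. A short chain ending in a carboxylic acid would help separate the effect of the end group from that of arm length.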